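The compounds below may be only part of what the source reports. "The series", "measured", "known", "first", "only" and "open" are said of these compounds alone.

For the measured compounds named here, compound 1 `O=C(Nc1ccccc1C(F)(F)F)C1CCc2ccccc2N1C(=O)c1ccccc1` is one of three compounds measured in a functional assay on NUGC-3 cells (Homo sapiens) for cytotoxicity, read by sulforhodamine B assay, with a stated time of 72 h; a higher number here means a weaker inhibitor of growth, a lower number a stronger inhibitor of growth. Compound 1 gives 8120 nM, the second highest of the three numbers. Compound 3 `O=C(Nc1ccccc1O)C1CCc2ccccc2N1C(=O)c1ccccc1` gives 3780 nM, and compound 2 `COc1ccc(NC(=O)C2CCc3ccccc3N2)cc1`, which lacks the benzoyl group on the shared core, gives 51900 nM. Going by the values given here, the only measured step between compounds that differ in a single place is a 2.1-fold lower number from compound 1 to compound 3 (0.33 log units; beyond the scatter); that step concerns a different aromatic ring from the benzoyl ring.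

Compound 4 `O=C(Nc1ccccc1C(F)(F)F)C1CCc2ccccc2N1C(=O)c1ccc(Cl)cc1` has not yet been measured. The change from compound 1 to compound 4 is chloro in place of hydrogen on an aromatic carbon, placed para to a large group on the benzoyl ring. Among the compounds with values here, no measured pair shows a change on that ring, so the numbers at hand point to no direction for this step. For compound 4 the expected step is therefore a 1.0-fold lower number from compound 1 to compound 4 (0.01 log units; within the scatter), within the scatter. Compound 4 is expected to give about 8000 nM in this assay, with a range from 3000 nM to 22000 nM.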

Compound 4, concentration for 50% growth inhibition: 551 nM
For compound 4 the middle estimate is 15-fold (1.16 log units) above the measured one, outside the stated range (below it).
By their numbers in this assay, from the lowest: compound 4; then compound 3; then compound 1; then compound 2.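

In this assay the benzoyl ring proves to be a place where one added atom matters: chloro in place of hydrogen, para to a large group, gives a 15-fold lower number from compound 1 to compound 4 (1.17 log units; beyond the scatter) with nothing else in the molecule changed. For the compounds shown here, the only earlier single-place step, a 2.1-fold lower number from compound 1 to compound 3 (0.33 log units; beyond the scatter) on the other aromatic ring, is modest, whereas this one is large, so the benzoyl ring is the first place in this set to show a large change. No measurement at hand explains why chloro has this effect here.

A single chloro compound cannot show whether the gain is particular to chloro or whether it depends on where the group sits on the ring. On these data alone, a bromo group or an amine at this position, chloro elsewhere on the ring, or chloro added to compound 3 would each help settle what remains open.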